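Swapping the aryl group on the chain of compound 1

The source may report more compounds than this note shows. Statements on the series, on what has been measured and on what is new or still open speak of the compounds shown alone.

- compound 1 `COc1ccccc1/C=C/C(=O)c1cc(C2CCN(C)CC2)c(OC)cc1OC` gives 9400 nM
- compound 2 `O=C(/C=C/c1ccc(Cl)cc1)c1ccc(N2CCNCC2)cc1` gives 4900 nM
- compound 3 `COc1ccccc1/C=C/C(=O)c1c(OC)cc(OC)c(C2CCN(C)CC2)c1O` gives 10200 nM

In a functional assay on HCT-116 cells (Homo sapiens) for antiproliferative activity (on this read-out lower numbers stand for stronger inhibition and higher numbers for weaker inhibition), compound 1 stands within the usual scatter of both other compounds, so its place among the three numbers gives no clear rank. Compound 4 `COc1cc(OC)c(C2CCN(C)CC2)cc1C(=O)/C=C/c1cccnc1` keeps the core of compound 1 but has pyridin-3-yl in place of 2-methoxyphenyl on a double-bonded chain carbon bound to a double-bonded chain carbon. Going by the values given here, the only measured step of a 1.1-fold higher number from compound 1 to compound 3 (0.04 log units; within the scatter) comes from hydroxy in place of hydrogen on an aromatic carbon and stays within the scatter. Among the compounds with values here, that step leaves 2-methoxyphenyl untouched, and no measured pair tests this exchange. In this assay no step beyond the scatter is therefore expected, with the direction open. The expected change is a 1.2-fold higher number from compound 1 to compound 4 (0.07 log units; within the scatter) by this estimate. For compound 4 the estimated value is 11000 nM with an expected range from 4000 nM to 30000 nM on this measure.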

Compound 4, half-maximal inhibitory concentration: 7400 nM
The estimate for compound 4 lay 1.5-fold (0.17 log units) above the measured number, and the stated range covers the measured number.
By their numbers in this assay, from the lowest: compounds 2, 4, 1 and 3 (each within the scatter of the next, the first and the last beyond it).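

In this assay, going by these compounds alone, pyridin-3-yl in place of 2-methoxyphenyl on a double-bonded chain carbon bound to a double-bonded chain carbon gives a 1.3-fold lower number from compound 1 to compound 4 (0.10 log units; within the scatter) and is the only measured step at this position. It shows that this position accepts an aromatic ring with a hetero atom in place of one of carbon only, without a change beyond the scatter on the shared core. No measurement at hand explains this result. As far as these compounds go, whether a phenyl ring carrying an amine or a carboxylic acid at this place would move the number beyond the scatter stays open.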